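A few compounds are considered here, and "the series" means these few. Any claim that something is new, unique, unknown or untested is made for them only; others in the source may bear on it.

In a functional assay on HeLa cells (Homo sapiens) for antiproliferative activity, read by MTT assay, with a stated time of 72 h (on this read-out lower numbers stand for stronger inhibition and higher numbers for weaker inhibition), compound 1 `O=C1O/C(=C\Cn2cc(-c3ccc(Br)cc3)nn2)C(OCc2ccccc2)=C1OCc1ccccc1` gives 24300 nM. Compound 2 `O=C1O[C@H]([C@@H](O)Cn2cc(-c3cccc(O)c3)nn2)C(OCc2ccccc2)=C1OCc1ccccc1` gives 39300 nM in this assay, the highest of the two numbers, with compound 1 the nearest and within the scatter. Compound 3 `COc1ccc(-c2cn(C/C=C3\OC(=O)C(OCc4ccccc4)=C3OCc3ccccc3)nn2)cc1` reaches only a limit of this assay, > 100000 nM. Within the data shown here, the one counted step, an at least 4.1-fold higher number from compound 1 to compound 3 (0.61 log units; beyond the scatter), concerns a substituent on the phenyl ring and not the change now at hand. Compound 4 `O=C1O[C@H]([C@@H](O)Cn2cc(CNS(=O)(=O)c3ccc(Cl)cc3)nn2)C(OCc2ccccc2)=C1OCc1ccccc1` differs from compound 2 by (((4-chlorophenyl)sulfonyl)amino)methyl in place of 3-hydroxyphenyl on an aromatic carbon. Among the measured compounds shown here, no measured step covers this exchange, so no shift beyond the scatter is expected in this assay, and the estimated step is a 1.0-fold higher number from compound 2 to compound 4 (0.01 log units; within the scatter). Compound 4 is thus expected to give about 40000 nM in this assay, between 10000 nM and 150000 nM.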

Compound 4, half-maximal inhibitory concentration: 13600 nM
Compound 4: middle estimate off by 2.9-fold (0.47 log units), on the high side; the range from low to high includes it.
By their numbers in this assay, from the lowest: compounds 4, 1 and 2 (each within the scatter of the next, the first and the last beyond it). At a limit, above all of these: compound 3.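

Among these compounds, at this carbon of the five-membered aromatic ring, the earlier compounds carried only a directly attached substituted phenyl ring. Compound 4 shows that this direct attachment is not required for activity: in this assay, (((4-chlorophenyl)sulfonyl)amino)methyl gives a 2.9-fold lower number from compound 2 to compound 4 (0.46 log units; beyond the scatter), a modest gain. Nothing measured here accounts for this shift.

The exchange alters the linking atoms and the ring substituent together, so their contributions remain unseparated. From the compounds shown here alone, it also remains open how a simple aminomethyl group or a plain alkyl chain at this carbon would read in this assay.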